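This account rests on a few compounds, and the source may have more. Where it says the series, first, only, none or still open, it means among the compounds named here.

Measured compounds:
compound 1, `Cc1c(C(=O)c2ccccc2)oc2ccc(NS(=O)(=O)c3ccc(F)cc3)cc12`: 10600 nM
compound 2, `Cc1c(C(=O)c2ccccc2)oc2ccc(NC(=O)c3ccc(F)cc3)cc12`: 18800 nM

In a functional assay on HeLa cells (Homo sapiens) for antiproliferative activity, read by MTT assay, with a stated time of 48 h (a lower number here means a stronger inhibitor, a higher number a weaker inhibitor), compound 1 gives 10600 nM. Compound 2 in this assay gives 18800 nM. Compound 1 has the lower of the two numbers, but the gap to compound 2 is within the scatter, so the two cannot be told apart on these data. Going by the values given here, the compounds share the core and differ at one point only; with two values this close, the pair gives no usable step.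

Compound 3, `CCOC(=O)c1oc2ccc(NS(=O)(=O)c3ccc(F)cc3)cc2c1C`, has not yet been measured in this assay. Relative to compound 1 it changes the substituent on the carbonyl carbon: ethoxy in place of phenyl on a carbonyl carbon. Among the compounds with values here, no measured pair shows this change, so its effect is unknown. Within the data shown here, since compound 1 gives 10600 nM and the only other value, that of compound 2, lies within the scatter of it, there is no trend to extrapolate. The expected step, a 1.4-fold higher number from compound 1 to compound 3 (0.15 log units; within the scatter), is therefore estimated as small, probably not beyond the scatter, with the direction open. For compound 3 the estimate in this assay is 15000 nM, with an expected range from 5000 nM to 45000 nM.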

Compound 3, half-maximal inhibitory concentration: 12200 nM
Estimate against measurement, compound 3: 1.2-fold (0.09 log units) above, and the stated range covers the measured number.
By their numbers in this assay, from the lowest: compounds 1, 3 and 2 (each within the scatter of the next).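

The first change shown at this position, ethoxy in place of phenyl on a carbonyl carbon, gives a 1.2-fold higher number from compound 1 to compound 3 (0.06 log units; within the scatter) in this assay. An aromatic ring of carbon only leaves and a ringless group carrying a hydrogen-bond acceptor enters, yet this read-out does not separate benzoyl from ethoxycarbonyl, so on these two compounds the phenyl ring is not required to keep the number at the level of compound 1. No measurement at hand bears on why the two groups read alike.

From the compounds shown here alone, whether any group on this carbonyl carbon can move the number beyond the scatter remains open: a carboxylic acid, a primary amide or a longer chain such as butoxy in place of ethoxy would test this position further. Also open is whether ethoxy in place of phenyl reads the same on the amide-linked compound 2, since the compounds shown give this change only on the sulfonamide of compound 1.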